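The compounds below may be only part of what the source reports. "The series", "measured", "known", "first", "only" and "open" are said of these compounds alone.

In a functional assay on B16 cells (Mus musculus) for cytotoxicity, read by MTT assay, with a stated time of 48 h (on this read-out higher numbers stand for weaker inhibition and lower numbers for stronger inhibition), compound 2 `COc1ccc(C(O)c2cn(CCCO)nn2)c(OC)c1OC` reaches only the limit of the assay, > 100000 nM, and no number is known for it. Compound 1 `COc1cccc(Cn2cc(-c3ccc(OC)c(OC)c3OC)nn2)c1` in this assay likewise gives only a limit, > 100000 nM. Both values shown thus sit at the same place, (the limit of > 100000 nM in this assay, at which 2 of the 2 values shown sit), and nothing in the data separates the two compounds from each other. Compound 3 `COc1cccc(Cn2cc(C(O)c3ccc(OC)c(OC)c3OC)nn2)c1` is the compound still to be measured in this assay. It differs from compound 2 in one place: 3-methoxyphenyl in place of 2-hydroxyethyl on a saturated chain carbon bound to an aromatic nitrogen. Going by the values given here, no step between two measured compounds exists in these data, and neither measured compound offers a number, so the size and direction of this change cannot be read from anything measured here. The expectation is that the change will stay within the usual scatter, with an estimated step that the limit leaves unreadable from compound 2 to compound 3, and that the assay will most probably report only a limit once more. The estimate for compound 3 in this assay is 120000 nM, expected to lie between 30000 nM and 500000 nM.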

Compound 3, half-maximal inhibitory concentration: > 100000 nM
Compound 3 gave a limit, no number; the forecaster's own chance of this, stated with the estimate: 75%; the middle value lies beyond the limit too.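

Going by these compounds alone, compound 2 and compound 3 both give a limit rather than a number, so no step between them can be read, neither its size nor its direction: the limit of > 100000 nM in this assay, at which 3 of the 3 values shown sit. The compounds shown leave open which change to the shared core, if any, would yield an actual number in this assay and so make a comparison possible.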